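The source may report more compounds than this note shows. Statements on the series, on what has been measured and on what is new or still open speak of the compounds shown alone.

Measured so far:
Compound 1 `COc1ccc2c(c1)CCCCN2c1nc(C)nc2ccccc12`: 18 nM
Compound 2 `COc1ccc2c(c1)CCCN(c1nc(Cl)nc3ccccc13)C2`: 6810 nM

In a functional assay on DU-145 cells (Homo sapiens) for cytotoxicity, read by sulforhodamine B assay (a lower number here means a stronger inhibitor of growth, a higher number a weaker inhibitor of growth), compound 2 gives 6810 nM, the higher of the two numbers, while compound 1 gives 18 nM, a gap well beyond the scatter. Compound 3 `COc1ccc2c(c1)CCCN(c1nc(C)nc3ccccc13)C2` keeps the core of compound 2 and has methyl in place of chloro on an aromatic carbon, between two ring nitrogen atoms: methyl in place of chloro on an aromatic carbon. Among the compounds with values here, no measured pair isolates this exchange, so its size is a matter of judgement. Compound 1 also carries a methyl and gives 18 nM, but its core differs from that of compound 2, so only part of that gap is expected to be recovered. A moderate step to a lower number in this assay, beyond the scatter, is therefore expected. The expected change is a 4.5-fold lower number from compound 2 to compound 3 (0.66 log units; beyond the scatter). Compound 3 is estimated at 1500 nM, with an expected range from 200 nM to 7000 nM.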

Compound 3, concentration for 50% growth inhibition: 14600 nM
Compound 3: the middle estimate sits 9.7-fold (0.99 log units) below what was measured, and the stated range ends below it.
By their numbers in this assay, from the lowest: compound 1; then compound 2; then compound 3.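

In this assay, methyl in place of chloro on this aromatic carbon, between two ring nitrogen atoms, gives a 2.1-fold higher number from compound 2 to compound 3 (0.33 log units; beyond the scatter) and so moves the number up rather than down. This position does respond to the exchange, but the step is modest, and both groups leave the core of compound 2 with a high number. On this core, then, a methyl at this position does not by itself give the low number seen for compound 1, which also carries a methyl. Nothing available here accounts for the direction of this step.

The compounds shown leave open whether chloro in place of methyl would move compound 1 in the same direction and by a similar amount. They also leave open how an amine or a longer chain such as propyl at this position would compare with methyl and chloro on either core.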